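Predicting a Methoxy Substitution in a Seizure Model Series

A few compounds are considered here, and "the series" means these few. Any claim that something is new, unique, unknown or untested is made for them only; others in the source may bear on it.

Three compounds have been measured in a functional assay on the whole organism (strain Swiss albino) with Mus musculus as the target, in the maximal electroshock model; a lower number here means that less compound is needed, a higher number that more compound is needed for the effect:

Compound 1 `C(=C/c1ccccc1)\C=N\Cc1cccnc1` gives 36.3 mg/kg.
Compound 2 `C(=N/Cc1cccnc1)\c1ccccc1` gives 53 mg/kg.
Compound 3 `Clc1ccc(/C=N/Cc2cccnc2)cc1` gives 53 mg/kg.

Compound 2 stands level with compound 3 at the digits shown, and together they have the highest numbers of the three; compound 1 sits at a lower number, but that gap is within the usual scatter of this assay, so no ordering among the three can be claimed.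

Compound 4 `COc1ccccc1/C=N/Cc1cccnc1` is not yet measured. It differs from compound 2 in one place: methoxy in place of hydrogen on an aromatic carbon.

Going by the values given here, the one measured step that resembles this change is no change at the digits printed from compound 2 to compound 3 (within the scatter), where a single small group entered an aromatic carbon of the same ring and the read-out stayed where it was. Among the compounds with values here, a methoxy is a different group from chloro, and the data hold no second example to show whether position on the ring matters, so this single step is the only guide.

On that basis the step of a 1.1-fold lower number from compound 2 to compound 4 (0.03 log units; within the scatter) is expected to stay within the scatter. Compound 4 is therefore estimated at 50 mg/kg, with a likely range from 25 mg/kg to 100 mg/kg.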

Compound 4, dose for half-maximal effect: 11.7 mg/kg
Compound 4: the middle estimate sits 4.3-fold (0.63 log units) above what was measured, outside the stated range (below it).
By their numbers in this assay, from the lowest: compound 4; then compounds 1, 2 and 3 (each within the scatter of the next).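

In this assay, a methoxy on an aromatic carbon, ortho to a group of 9 heavy atoms, gives a 4.5-fold lower number from compound 2 to compound 4 (0.66 log units; beyond the scatter) and so lowers the dose needed for the effect by more than the usual scatter. The earlier step of no change at the digits printed from compound 2 to compound 3 (within the scatter) stayed within the scatter, so compound 3 had given no sign that a single new group on this ring could shift the read-out; compound 4 shows that it can, although compound 3 still stands as the case where the read-out held. No accompanying measurement bears on what lies behind this step, and two compounds cannot show whether the group itself, its place on the ring, or both account for the difference from the chloro step.

On these data alone, whether a methoxy on another carbon of the ring would give a similar step remains open, as does whether a hydroxyl, an ethoxy or an amine in the same place would match it. As far as these compounds go, it also remains open whether the same methoxy would have a similar effect on the core of compound 1.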